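The compounds below may be only part of what the source reports. "The series", "measured", "known", "first", "only" and "open" are said of these compounds alone.

Compound 1 `COc1ccc(C(=O)/C=C/c2cccc([N+](=O)[O-])c2)c2c1C=CC(C)(C)O2` and compound 2 `COc1ccc(C(=O)/C=C/c2ccccc2)c2c1C=CC(C)(C)O2` share one core and differ only in a nitro group on the aromatic ring. In a functional assay on HepG2 cells (Homo sapiens) for antiproliferative activity, read by MTT assay, with a stated time of 24 h (on this read-out lower numbers stand for stronger inhibition and higher numbers for weaker inhibition), compound 1 gives 2830 nM. Compound 2 reaches only the limit of the assay, > 10000 nM, so for compound 2 the number is not known, only a limit (the limit of > 10000 nM in this assay, at which 1 of the 2 values shown sits). The step of an at least 3.5-fold higher number from compound 1 to compound 2 (0.54 log units; beyond the scatter) therefore shows that removing the nitro group weakens the effect by at least a modest amount. Compound 3 `COc1ccc(C(=O)/C=C/c2cccc(C(F)(F)F)c2)c2c1C=CC(C)(C)O2` is not yet measured; it differs from compound 2 by trifluoromethyl in place of hydrogen on an aromatic carbon. For the measured compounds named here, only the step from compound 1 to compound 2 bears on this change, and it points the same way: a group at this place was linked to a lower number. A modest fall is therefore expected, an at least 2.2-fold lower number from compound 2 to compound 3 (0.34 log units; beyond the scatter), though the group is a different one. Compound 3 is estimated at 4500 nM, between 1500 nM and 15000 nM.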

Compound 3, half-maximal inhibitory concentration: > 10000 nM
Compound 3: no number, only a limit; the forecaster's own chance of this, stated with the estimate: 35%; middle value at least 2.2-fold (0.34 log units) away from the limit.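

In this assay, trifluoromethyl does not do what nitro does at this place: replacing nitro with trifluoromethyl gives an at least 3.5-fold higher number from compound 1 to compound 3 (0.54 log units; beyond the scatter). The earlier pair suggested that a group here might lower the number, but this result shows that not every group does so, and among the three compounds only compound 1, the nitro compound, gives a number rather than a limit. The step between compound 2 and compound 3 cannot be read, since both stand at a limit: the limit of > 10000 nM in this assay, at which 2 of the 3 values shown sit.

Going by these compounds, how far compound 3 truly lies from compound 2 stays open, and so does whether nitro would give a similar result elsewhere on the ring. Also open, on these data alone, is whether an amine, a carboxylic acid or a nitrile at this place would give a number, as nitro does in compound 1.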